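Aryl variation on the hydrazone carbon: cytotoxicity working notes

The compounds below may be only part of what the source reports. "The series", "measured", "known", "first", "only" and "open" are said of these compounds alone.

Compound 1 `CN(C)CCn1cnnc1-c1cc(Oc2ccc(NC(=O)N/N=C/c3c(Cl)cccc3Cl)cc2F)ccn1`, compound 2 `CN(C)CCn1cnnc1-c1cc(Oc2ccc(NC(=O)N/N=C/c3c[nH]c4ccccc34)cc2F)ccn1` and compound 3 `CN(C)CCn1cnnc1-c1cc(Oc2ccc(NC(=O)N/N=C/c3ccc(F)cc3)cc2F)ccn1` share one core and differ only in the aryl group on the carbon with a double bond to nitrogen. In an ADME assay on WI-38 cells (Homo sapiens) for cytotoxicity, read by MTT assay, with a stated time of 72 h (a higher number here means a weaker inhibitor, a lower number a stronger inhibitor), compound 1 gives 3320 nM, compound 2 gives 3620 nM and compound 3 gives 3980 nM. Compound 3 carries the highest of the three numbers, but the steps of a 1.2-fold higher number from compound 1 to compound 3 (0.08 log units; within the scatter) and a 1.1-fold higher number from compound 2 to compound 3 (0.04 log units; within the scatter) both stay within the scatter, as does a 1.1-fold higher number from compound 1 to compound 2 (0.04 log units; within the scatter), so the three compounds cannot be told apart in this assay. Compound 4 `CN(C)CCn1cnnc1-c1cc(Oc2ccc(NC(=O)N/N=C/c3c(O)ccc4ccccc34)cc2F)ccn1` is not yet measured; it carries the change (2-hydroxynaphthalen-1-yl in place of 4-fluorophenyl on a carbon with a double bond to nitrogen). The measured steps that bear on it are the two aryl exchanges at this same position leading to compound 3, and neither moved the number beyond the scatter. Compound 4 is therefore expected to show a 1.0-fold lower number from compound 3 to compound 4 (0.01 log units; within the scatter) in this assay. Compound 4 is estimated at 3900 nM in this assay, with a range from 1600 nM to 9500 nM.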

Compound 4, half-maximal inhibitory concentration: 3250 nM
Beside the measured number, compound 4's estimate is 1.2-fold (0.08 log units) above it; low and high end bracket the measured number.
By their numbers in this assay, from the lowest: compounds 4, 1, 2 and 3 (each within the scatter of the next).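

Notes on the new step: at the carbon with a double bond to nitrogen, 2-hydroxynaphthalen-1-yl, with 11 heavy atoms against 7 in 4-fluorophenyl and with a hydrogen-bond donor and acceptor, still gives a step within the scatter (a 1.2-fold lower number from compound 3 to compound 4 (0.09 log units; within the scatter)). The exchanges from the other two aryl groups also stay within the scatter (a 1.1-fold lower number from compound 2 to compound 4 (0.05 log units; within the scatter); a 1.0-fold lower number from compound 1 to compound 4 (0.01 log units; within the scatter)), so the series now shows that a hydroxyl-bearing aryl group of two six-membered carbon rings cannot be told apart from the earlier three in this assay. No supporting data on hand explain this flat result.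

Still open, on these data alone, is whether an amine, a carboxylic acid or a longer alkyl chain in place of the aryl group would move the number beyond the scatter. Also open, as far as these compounds go, is whether a change elsewhere on the shared core would do so.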